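Methyl Added at Two Places in the Same Core

The source may hold more compounds than are shown below. What is called first, only, known or untested is meant among the compounds shown, and "the series" means these compounds.

The measured compounds:
compound 1 `CCCCCOc1ccc2[nH]c(-c3ccc(OC)cc3)c(C3=C(Br)C(=O)NC3=O)c2c1`, 3.77
compound 2 `CCCCCCOc1ccc2[nH]c(-c3ccc(OC)cc3)c(C3=C(Br)C(=O)NC3=O)c2c1`, 4.1
compound 3 `COc1ccc(-c2[nH]c3c(C)cccc3c2C2=C(Br)C(=O)NC2=O)cc1`, 3.12

In a physicochemical assay for lipophilicity (a lower number here means a more polar compound, a higher number a more lipophilic compound), compound 1 gives 3.77. Compound 2 gives 4.1 in this assay, and compound 3 gives 3.12, the lowest of the three. The change methyl in place of hydrogen on a saturated chain carbon, five bonds along the chain from an oxygen on an aromatic ring produced a number 0.33 log units higher from compound 1 to compound 2 (beyond the scatter). Compound 4 `CCc1cccc2c(C3=C(Br)C(=O)NC3=O)c(-c3ccc(OC)cc3)[nH]c12` is not yet measured; it differs from compound 3 by methyl in place of hydrogen on a saturated chain carbon bound to an aromatic carbon. This is the same kind of change, but the place differs: in the earlier pair the carbon sits five bonds along the chain from an oxygen on an aromatic ring, whereas here it is bound directly to an aromatic carbon. The difference between the cores of compound 1 and compound 3 is not broken down here. A step of a number 0.38 log units higher from compound 3 to compound 4 (beyond the scatter) is expected for compound 4, resting on the step of a number 0.33 log units higher from compound 1 to compound 2 (beyond the scatter). Compound 4 is therefore estimated at 3.5, between 3.2 and 3.85.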

Compound 4, partition coefficient: 3.35
The estimate for compound 4 lay 0.15 log units above the measured number; the measured number falls inside the stated range.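

In this assay, the methyl to ethyl change on the core of compound 3 gave a number 0.23 log units higher from compound 3 to compound 4 (within the scatter) against a number 0.33 log units higher from compound 1 to compound 2 (beyond the scatter) for the same kind of change on the core of compound 1. The step seen on the first core therefore did not emerge beyond the scatter on the second, but these two pairs differ in both core and place, so they cannot show which of the two governs the size of the step. Nothing available bears on why the two steps came out as they did.

The compounds shown leave open whether a propyl or longer chain on the core of compound 3 would stand clear of the scatter. They also leave open how an amine or a carboxylic acid on that chain would read.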